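The source may report more compounds than this note shows. Statements on the series, on what has been measured and on what is new or still open speak of the compounds shown alone.

Compound 1, `CC/N=C(\S)NCCCCCn1nc(-c2ccccc2)ccc1=O`, gives 66.4% in a functional assay on the whole organism with Rattus norvegicus as the target, at a dose of 100 mg/kg; a higher number here means more inhibition at the dose given (going by the name of the read-out), a lower number less inhibition. Compound 2, `CCC/N=C(/NC#N)NCCCCCn1nc(-c2ccccc2)ccc1=O`, gives 27.5% in this assay.

Within the data shown here, compound 2 stands lowest of the two numbers in this assay; the single measured step, a number 38.9 percentage points lower from compound 1 to compound 2 (beyond the scatter), separates it from compound 1 and lies beyond the scatter. Compound 3, `CC/N=C(/NC#N)NCCCCCCn1nc(-c2ccccc2)ccc1=O`, differs from compound 2 by a group of 9 heavy atoms (5 carbon, 4 nitrogen; no ring) in place of a group of 9 heavy atoms (5 carbon, 4 nitrogen; no ring), on a saturated chain carbon, five bonds along the chain from an aromatic nitrogen; the two have the same atoms, joined differently. Among the measured compounds shown here, no measured step touches this part of the molecule: the one step known, a number 38.9 percentage points lower from compound 1 to compound 2 (beyond the scatter), exchanges the group on the amine nitrogen and leaves the chain unchanged, so it shows only how far inhibition in this assay can move within this pair. With nothing closer to go on, the expected step of a number 2.5 percentage points higher from compound 2 to compound 3 (within the scatter) is small, not beyond the scatter in either direction. Compound 3 is therefore estimated at 30%, with a range from 10% to 55%.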

Compound 3, a percentage reported as inhibition, in the whole organism at one dose (the size of the read-out at that dose, not a potency): 29.1%
Compound 3: middle estimate off by 0.9 percentage points, on the high side; the measured number falls inside the stated range.
By their numbers in this assay, from the lowest: compounds 2 and 3 (each within the scatter of the next); then compound 1.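

In this assay, the rearrangement of the same atoms on a saturated chain carbon, five bonds along the chain from an aromatic nitrogen, gives a number 1.6 percentage points higher from compound 2 to compound 3 (within the scatter), so this first look at the position shows no change that stands out from the scatter. The large step of a number 37.3 percentage points lower from compound 1 to compound 3 (beyond the scatter) shows that compound 3, like compound 2, stays well apart from compound 1, so among these three compounds the gap follows the two nitrile-bearing groups in either arrangement. Nothing at hand explains either step.

As far as these compounds go, whether a longer chain, or a primary amine in place of the group on the amine nitrogen, would move inhibition in this assay remains open. From the compounds shown here alone, it is also open whether the sulfur-bearing group of compound 1 would hold its number on the chain of compound 3.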